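This account rests on a few compounds, and the source may have more. Where it says the series, first, only, none or still open, it means among the compounds named here.

Of the compounds shown here, three built on one shared core have been measured in an assay on isolated protein for binding affinity to 5-hydroxytryptamine receptor 4 (Homo sapiens); a lower number here means a stronger inhibitor, a higher number a weaker inhibitor. In this assay compound 1 `CC(=O)N1CCN(CCN2CCC(CNC(=O)c3cccc4[nH]c(C(C)C)nc34)CC2)CC1` gives 5.01 nM, compound 2 `COC(=O)N(C)CC(O)CN1CCC(CNC(=O)c2cccc3[nH]c(C(C)C)nc23)CC1` gives 3.98 nM, and compound 3 `CC(=O)N(C)CC(O)CN1CCC(CNC(=O)c2cccc3[nH]c(C(C)C)nc23)CC1` gives 3.98 nM. Compound 3 thus stands level with compound 2 at the digits shown. Every step among these three stayed within the scatter: a 1.3-fold lower number from compound 1 to compound 2 (0.10 log units; within the scatter), a 1.3-fold lower number from compound 1 to compound 3 (0.10 log units; within the scatter) and no change at the digits printed from compound 2 to compound 3 (within the scatter). Compound 4 `CC(=O)N1CCC(CN2CCC(CNC(=O)c3cccc4[nH]c(C(C)C)nc34)CC2)CC1` differs from compound 3 by 1-acetylpiperidin-4-yl in place of 2-(acetyl(methyl)amino)-1-hydroxyethyl on a saturated chain carbon bound to an amine nitrogen in a ring. The most relevant measured step is a 1.3-fold lower number from compound 1 to compound 3 (0.10 log units; within the scatter), run in reverse, since compound 1 with its (4-acetylpiperazin-1-yl)methyl group is the closest measured analogue of compound 4. Within the data shown here, no step has moved this assay beyond the scatter, and none is expected here. Compound 4 is therefore estimated at 4.5 nM, with a range of 2 nM to 10 nM. The expected step reads a 1.1-fold higher number from compound 3 to compound 4 (0.05 log units; within the scatter).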

Compound 4, inhibition constant: 1 nM
Compound 4: the middle estimate sits 4.5-fold (0.65 log units) above what was measured; the measured number lies below the stated range.
By their numbers in this assay, from the lowest: compound 4; then compounds 2, 3 and 1 (each within the scatter of the next).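

Among these compounds, at the saturated chain carbon bound to an amine nitrogen in a ring, 1-acetylpiperidin-4-yl gives the only steps beyond the scatter in this assay so far: a 4.0-fold lower number from compound 3 to compound 4 (0.60 log units; beyond the scatter) and a 4.0-fold lower number from compound 2 to compound 4 (0.60 log units; beyond the scatter) and a 5.0-fold lower number from compound 1 to compound 4 (0.70 log units; beyond the scatter) in turn. This position therefore does respond to the group it carries, although the three earlier groups gave numbers within the scatter of one another. No measurement shown bears on what lies behind this result.

Going by these compounds, whether the acetyl is needed remains open. A free piperidine amine or a methanesulfonyl group on that ring nitrogen would test this.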